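The source may report more compounds than this note shows. Statements on the series, on what has been measured and on what is new or still open speak of the compounds shown alone.

The series shares one core, carried by compound 1 `CCOC(=O)c1c(-c2cccc(Cl)c2)[nH]c2cc(OC)ccc2c1=O`, compound 2 `CCOC(=O)c1c(-c2ccc(Cl)c(Cl)c2)[nH]c2cccc(OC)c2c1=O` and compound 3 `CCOC(=O)c1c(-c2ccc(C(C)(C)C)cc2)[nH]c2cccc(OC)c2c1=O`. In a physicochemical assay for solubility, in phosphate buffer, at pH 7.4 (on this read-out higher numbers stand for higher solubility and lower numbers for lower solubility), compound 1 gives 58000 nM. In this assay compound 2 gives 39000 nM, a number that sits within the scatter of compound 1, so the two are not told apart. In this assay compound 3 gives 1000 nM, far below compound 1 and beyond the scatter. Compound 4 `CCOC(=O)c1c(-c2ccc(Cl)c(Cl)c2)[nH]c2cc(OC)ccc2c1=O` has not yet been measured; it differs from compound 1 by chloro in place of hydrogen on an aromatic carbon, a chloro group entering on an aromatic carbon of a six-membered aromatic ring of carbon only. Among the measured compounds shown here, no measured pair shows this exact step. Compound 2, which carries the same 3,4-dichlorophenyl group on a core with its methoxy group at another position, stays near compound 1, so the expected step of a 1.9-fold lower number from compound 1 to compound 4 (0.29 log units; within the scatter) is a small decrease, probably within the scatter. Compound 4 is therefore estimated at 30000 nM, with a range from 12000 nM to 70000 nM.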

Compound 4, solubility: 17000 nM
The estimate for compound 4 lay 1.8-fold (0.25 log units) above the measured number; low and high end bracket the measured number.
By their numbers in this assay, from the lowest: compound 3; then compound 4; then compounds 2 and 1 (each within the scatter of the next).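

In this assay, among the compounds shown here, going from 3-chlorophenyl to 3,4-dichlorophenyl gives the first direct reading of this change on the shared core (a 3.4-fold lower number from compound 1 to compound 4 (0.53 log units; beyond the scatter)), a modest step but one that lies beyond the scatter. The earlier compounds shown here offered no such pair, and this one shows that a single chloro group entering on this aromatic carbon, ortho to a chloro group and para to a large group, is enough to separate two compounds on this read-out. Nothing at hand accounts for the size of this step.

On these data alone, what a fluoro group, a nitrile or an amine would do in this same place remains open. Also open, as far as these compounds go, is whether the step would hold on a core with its methoxy group at another position, as in compound 2.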